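A few compounds are considered here, and "the series" means these few. Any claim that something is new, unique, unknown or untested is made for them only; others in the source may bear on it.

Compound 3 `CN(C)c1c(F)c(N)c2c(=O)cc(-c3ccc(N)c(F)c3)oc2c1F` stands at the edge of what the measurement can report: in a functional assay on HeLa cells (Homo sapiens) for cytotoxicity, read by neutral red uptake, with a stated time of 3 days (a lower number here means a stronger inhibitor, a higher number a weaker inhibitor), compound 3 gives > 100000 nM, which is a limit of the assay and not a number. Compound 1 `Nc1ccc(-c2cc(=O)c3c(N)c(F)c(Br)c(F)c3o2)cc1F` gives > 100000 nM, also a limit. Compound 2 `Nc1ccc(-c2cc(=O)c3c(N)c(F)c(CO)c(F)c3o2)cc1F` gives 24000 nM. Compound 4 `CCCCCC(=O)OCc1c(F)c(N)c2c(=O)cc(-c3ccc(N)c(F)c3)oc2c1F` differs from compound 3 by ((pentylcarbonyl)oxy)methyl in place of dimethylamino on an aromatic carbon. Among the measured compounds shown here, two measured steps touch this position: a step that the two limits leave unreadable from compound 1 to compound 3 and an at least 4.1-fold higher number from compound 2 to compound 3 (0.61 log units; beyond the scatter). For the measured compounds named here, because the limit of > 100000 nM in this assay, at which 2 of the 3 values shown sit, hides the true value of compound 3, only the step from compound 2 is readable. Compound 4 is expected to give an estimated 30000 nM, within 8000 nM to 150000 nM. The expected step is an at least 3.3-fold lower number from compound 3 to compound 4 (0.52 log units; beyond the scatter), a lower number.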

Compound 4, half-maximal inhibitory concentration: 34000 nM
Compound 4: middle estimate off by 1.1-fold (0.05 log units), on the low side; low and high end bracket the measured number.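

Putting pentylcarbonyl in place of hydrogen on the hydroxymethyl oxygen gives a 1.4-fold higher number from compound 2 to compound 4 (0.15 log units; within the scatter), so compound 2 and compound 4 read alike and the free hydroxyl is not required for a measurable value at this position. The ester also stands apart from the bromo and dimethylamino groups, with an at least 2.9-fold lower number from compound 3 to compound 4 (0.46 log units; beyond the scatter) and an at least 2.9-fold lower number from compound 1 to compound 4 (0.46 log units; beyond the scatter). Compound 1 and compound 3 each sit at a limit, not a number: the limit of > 100000 nM in this assay, at which 2 of the 4 values shown sit.

Still open, as far as these compounds go, is whether a methoxymethyl ether, an amide or a carboxylic acid at this position would also give a measurable value. From the compounds shown here alone, how a shorter acyl chain would read also remains open.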